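A Hydroxy Group on the Anilino Ring of Compound 1

The source may report more compounds than this note shows. Statements on the series, on what has been measured and on what is new or still open speak of the compounds shown alone.

Three compounds have so far been measured in a functional assay on MCF7 cells (Homo sapiens) for inhibition, read by fluorescence, with a stated time of 72 h; a lower number here means a stronger inhibitor of growth, a higher number a weaker inhibitor of growth:

compound 1, `CC(C)CCn1cnc2c(Nc3ccccc3)nc(N[C@H]3CC[C@H](N)CC3)nc21`: 5400 nM
compound 2, `CCCCCCn1cnc2c(Nc3cccc(Cl)c3)nc(N[C@H]3CC[C@H](N)CC3)nc21`: 2700 nM
compound 3, `CCCCn1cnc2c(Nc3ccccc3)nc(N[C@H]3CC[C@H](N)CC3)nc21`: 2200 nM

Compound 1 gives the highest of the three numbers. Its gap to compound 2 lies within the scatter, so those two cannot be told apart on the numbers shown, whereas compound 3 sits clearly lower, by a 2.5-fold lower number from compound 1 to compound 3 (0.39 log units; beyond the scatter); that step shortens the chain on the core and leaves the anilino ring untouched.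

The new compound 4, `CC(C)CCn1cnc2c(Nc3ccc(O)cc3)nc(N[C@H]3CC[C@H](N)CC3)nc21`, differs from compound 1 in one place: hydroxy in place of hydrogen on an aromatic carbon. Going by the values given here, no measured step bears on this change. Among the compounds with values here, the one step in hand concerns the chain, not the ring, and compound 2, which does carry a substituent on the anilino ring, also carries a different chain, so its value cannot be split into the two contributions. With nothing to lean on, the expectation for compound 4 is a step of a 1.2-fold lower number from compound 1 to compound 4 (0.08 log units; within the scatter), that is, no change beyond the scatter. The estimate for compound 4 is therefore 4500 nM, with a range from 1400 nM to 14000 nM. That range is wide: the data give no guide to this kind of change.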

Compound 4, concentration for 50% growth inhibition: 3100 nM
Compound 4: the middle estimate sits 1.5-fold (0.16 log units) above what was measured; the range from low to high includes it.
By their numbers in this assay, from the lowest: compounds 3, 2, 4 and 1 (each within the scatter of the next, the first and the last beyond it).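

Replacing phenyl with 4-hydroxyphenyl on the core of compound 1 gives a 1.7-fold lower number from compound 1 to compound 4 (0.24 log units; within the scatter) in this assay, the only step shown that changes the anilino ring while the chain stays the same. This step cannot be told apart from no change, so a hydroxy group at this spot, para to a large group, shows no effect on growth inhibition that rises above the usual variation between repeat measurements. Nothing measured here speaks to how the hydroxy group acts at this spot, or to whether it matters at all.

As far as these compounds go, it remains open whether a different group at this same spot, such as an amine, a methoxy group or a carboxylic acid, would produce a step beyond the scatter, or would likewise leave the number where it is. Also open, from the compounds shown here alone, is whether the hydroxy group would give a similarly small step on the shorter chain of compound 3, the compound with the lowest number so far, since a single pair cannot show whether the result holds on another chain.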